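From Benzamido to (Cyanomethyl)sulfanyl on the Shared Core

The source may hold more compounds than are shown below. What is called first, only, known or untested is meant among the compounds shown, and "the series" means these compounds.

In a functional assay on HepG2 cells (Homo sapiens) for antiproliferative activity, read by MTT assay, with a stated time of 48 h (on this read-out lower numbers stand for stronger inhibition and higher numbers for weaker inhibition), compound 2 `Cc1ccc(-c2nc(NC(=O)c3ccccc3)c3cc(Cl)ccc3n2)cc1` gives 17.5 ug/mL. This lies within the scatter of compound 1 `Cc1ccc(-c2nc3ccc(Cl)cc3c(=O)[nH]2)cc1` at 9.86 ug/mL and of compound 3 `Cc1ccc(-c2nc(NOC(=O)c3ccccc3)c3cc(Cl)ccc3n2)cc1` at 12.1 ug/mL, so the three values are not told apart. Compound 4 `Cc1ccc(-c2nc(SCC#N)c3cc(Cl)ccc3n2)cc1` differs from compound 2 by one exchange: (cyanomethyl)sulfanyl in place of benzamido on an aromatic carbon. Within the data shown here, the only measured step at this place is a 1.4-fold lower number from compound 2 to compound 3 (0.16 log units; within the scatter), and it keeps the benzoyl group, so it is only a weak guide to losing the ring. Among the measured compounds shown here, no measured compound carries the (cyanomethyl)sulfanyl group. No shift beyond the scatter is therefore expected in this assay, and the expected change is a 1.5-fold lower number from compound 2 to compound 4 (0.16 log units; within the scatter). For compound 4 the estimated value is 12 ug/mL, within an expected range of 5 ug/mL to 30 ug/mL.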

Compound 4, half-maximal inhibitory concentration: 4.37 ug/mL
Beside the measured number, compound 4's estimate is 2.7-fold (0.44 log units) above it; measured number below the stated range.
By their numbers in this assay, from the lowest: compound 4; then compounds 1, 3 and 2 (each within the scatter of the next).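

In this assay, among these compounds, the exchange of benzamido for (cyanomethyl)sulfanyl on this aromatic carbon brings a 4.0-fold lower number from compound 2 to compound 4 (0.60 log units; beyond the scatter) and so gives the first step at this place that lies beyond the scatter. The earlier step here kept the benzoyl group and its six-membered aromatic ring, whereas this one gives up that ring, and the number moves. Nothing available explains the shift. The compounds shown leave open whether the sulfur, the nitrile or the loss of benzamido carries the step. On these data alone, how a plain methylsulfanyl group or a longer chain ending in a nitrile would read at this place also stays open.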